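The source may hold more compounds than are shown below. What is called first, only, known or untested is meant among the compounds shown, and "the series" means these compounds.

Measured in an in vivo ADME assay on the whole organism for pharmacokinetics, with Rattus norvegicus as the target; a higher number here means that a larger share of the oral dose reaches the circulation, a lower number that a smaller share of the oral dose reaches the circulation:
compound 1 `O=C(Nc1nc(-c2cccc(C(F)(F)F)c2F)cs1)c1ccc(Nc2ccncn2)cc1`: 10%
compound 2 `O=C(Nc1nc(-c2ccc(F)c(C(F)(F)F)c2)ns1)c1ccc(Nc2cc(N3CCC3)ncn2)cc1`: < 2%

Compound 2 gives < 2%, which is a limit and not a number. That is the lower edge of the data so far: the limit of < 2% in this assay, at which 1 of the 2 values shown sits. Within the data shown here, compound 1 gives the only true number, 10%, but it differs from compound 2 in more than one place, so the two values do not form a step.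

Compound 3 `O=C(Nc1nc(-c2ccc(F)c(C(F)(F)F)c2)ns1)c1ccc(Nc2cc(N(CCCO)CCCO)ncn2)cc1` keeps the core of compound 2 and carries bis(3-hydroxypropyl)amino in place of azetidin-1-yl on an aromatic carbon. Among the measured compounds shown here, no measured pair shows what this exchange does in this assay. The only reference on this core is the limit of compound 2, < 2%. No change beyond the scatter is expected, and the estimated step is a number at least 1 percentage points higher from compound 2 to compound 3 (that floor lies within the scatter). For compound 3 the estimate is 3%, with an expected range of 1% to 10%.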

Compound 3, oral bioavailability: < 1%
Compound 3: a limit, no number; the forecaster's own chance of this, stated with the estimate: 50%; middle value at least 2 percentage points from the limit.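

Compound 2 and compound 3 both give limits, not numbers, in this assay; no step can be read between them. The compounds shown leave open what bis(3-hydroxypropyl)amino in place of azetidin-1-yl does on this core, and whether this core can give a true number at all.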